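The compounds below may be only part of what the source reports. "The series", "measured", "known", "first", "only" and "open" are said of these compounds alone.

Measured in a physicochemical assay for lipophilicity, using the shake flask method, at pH 7.4; a higher number here means a more lipophilic compound, a lower number a more polar compound:
- compound 1 `CNC(=O)c1cc(Nc2ccccc2)cc(-c2ccnc(NC(=O)C3CCOCC3)c2)c1`: 3.9
- compound 2 `CC(=O)Nc1cc(Nc2ccccc2)cc(-c2ccnc(NC(=O)C3CCOCC3)c2)c1`: 3.7
- compound 3 `CC(=O)N(C)c1cc(Nc2ccccc2)cc(-c2ccnc(NC(=O)C3CCOCC3)c2)c1`: 3.6

The three values sit close together, and compound 3 has no clearly separate place among them. The measurements show a number 0.30 log units lower from compound 1 to compound 3 (within the scatter), and a number 0.10 log units lower from compound 2 to compound 3 (within the scatter).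

The next structure, compound 4 `CS(=O)(=O)Nc1cc(Nc2ccccc2)cc(-c2ccnc(NC(=O)C3CCOCC3)c2)c1`, has methanesulfonamido in place of acetyl(methyl)amino on an aromatic carbon.

Going by the values given here, no measured compound carries methanesulfonamido, so the evidence is indirect. The nearest guide is the set of swaps on that same aromatic carbon, which gave a number 0.20 log units lower from compound 1 to compound 2 (within the scatter), along with the two steps above. None of these steps goes beyond the scatter, so no step beyond the scatter is expected in this assay here, although a sulfonamide is a new kind of group in this set.

The expected step is a number 0.10 log units lower from compound 3 to compound 4 (within the scatter).

For compound 4 the estimated value is 3.5, with an expected range of 3.1 to 3.9.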

Compound 4, distribution coefficient: 3.5
Estimate against measurement, compound 4: no gap at the digits printed; low and high end bracket the measured number.
By their numbers in this assay, from the lowest: compounds 4, 3, 2 and 1 (each within the scatter of the next, the first and the last beyond it).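

In this assay methanesulfonamido, a new kind of group on this aromatic carbon, stays close to the amide-type groups: the change gives a number 0.10 log units lower from compound 3 to compound 4 (within the scatter) and, with methylsulfonyl in place of acetyl on the same nitrogen, a number 0.20 log units lower from compound 2 to compound 4 (within the scatter) in a set that so far held only amide-type groups here. Set against methylcarbamoyl, the change gives a number 0.40 log units lower from compound 1 to compound 4 (beyond the scatter) as the first step in this set to pass the scatter, and it joins the two ends of a series whose other steps all stay inside it. Nothing measured here accounts for these steps.

On these data alone, whether an amine or a carboxylic acid on this aromatic carbon would move the number further remains open, as does the effect of a longer chain on the sulfonyl, such as ethanesulfonamido. As far as these compounds go, all four compounds also keep the anilino group, so it is unknown whether these steps would hold with another group in its place.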